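This account rests on a few compounds, and the source may have more. Where it says the series, first, only, none or still open, it means among the compounds named here.

Measured in a toxicity assay on THP-1 cells (Homo sapiens) for inhibition; on this read-out higher numbers stand for lower toxicity in this test and lower numbers for higher toxicity in this test:
- compound 1 `COc1ccc(-c2cnc(NC(=O)C3CCCC3)n2C)cc1`: > 100000 nM
- compound 2 `COc1ccc(-c2cnc(NC(=O)c3ccn[nH]3)n2C)cc1`: > 100000 nM
- compound 3 `CCCC(=O)Nc1ncc(-c2ccc(OC)cc2)n1C`: > 100000 nM

Each of these values is a limit of this assay, not a number; compound 3 therefore stands at the limit, with no measured position within the range. Compound 4 `COc1ccc(-c2cnc(NC(=O)c3ccc(Cl)cc3)n2C)cc1` differs from compound 3 as follows: 4-chlorophenyl in place of propyl on a carbonyl carbon. For the measured compounds named here, the steps that bear on a change at this carbonyl carbon are a step that the two limits leave unreadable from compound 1 to compound 3 and a step that the two limits leave unreadable from compound 2 to compound 3; neither has a readable size, since (the limit of > 100000 nM in this assay, at which 3 of the 3 values shown sit). No direction or size of step in this assay can therefore be expected beyond the scatter, and compound 4 is most likely to return a limit as well. Compound 4 is estimated at 100000 nM (range 30000 nM to 300000 nM). The expected step of a number no higher from compound 3 to compound 4 (the limit leaves the size open) is thus essentially flat.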

Compound 4, half-maximal cytotoxic concentration: > 100000 nM
Compound 4 gave a limit, no number; the forecaster's own chance of this, stated with the estimate: 80%; the middle value lies on the limit itself.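

No step can be read among compound 1, compound 2, compound 3 and compound 4 in this assay: the limit of > 100000 nM in this assay, at which 4 of the 4 values shown sit.

The compounds shown leave open whether the groups on the carbonyl carbon differ at all in this read-out.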